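A few compounds are considered here, and "the series" means these few. Any claim that something is new, unique, unknown or untested is made for them only; others in the source may bear on it.

Of the compounds shown here, two with a shared core have been tested so far: compound 1 `C=C1[C@@H](OC(C)=O)C[C@@H]2[C@](C)(COC=O)[C@H](OC(C)=O)CC[C@@]2(C)[C@@H]1C[C@@H](Nc1ccc(F)cc1)C1=CCOC1=O` and compound 2 `C=C1[C@@H](OC(C)=O)C[C@@H]2[C@](C)(CO[Si](C)(C)C(C)(C)C)[C@H](OC(C)=O)CC[C@@]2(C)[C@@H]1C[C@@H](Nc1ccc(C(=O)O)cc1)C1=CCOC1=O`. In a functional assay on A549 cells (Homo sapiens) for cytotoxicity, read by sulforhodamine B assay (a higher number here means a weaker inhibitor, a lower number a stronger inhibitor), compound 1 gives 21300 nM and compound 2 gives 4210 nM. Compound 2 therefore holds the lower of the two numbers, and the gap between them lies beyond the usual scatter of repeated measurements.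

Compound 3 `C=C1[C@@H](OC(C)=O)C[C@@H]2[C@](C)(COC=O)[C@H](OC(C)=O)CC[C@@]2(C)[C@@H]1C[C@@H](Nc1ccc(C(=O)O)cc1)C1=CCOC1=O` is compound 2 with a single change: a group of 2 heavy atoms (1 carbon, 1 oxygen; no ring) in place of a group of 7 heavy atoms (6 carbon, 1 silicon; no ring), on an oxygen on a saturated carbon. A formyl group takes the place of the group of 7 heavy atoms, on an oxygen on a saturated carbon. Within the data shown here, no measured pair isolates this swap, since compound 1 and compound 2 differ in more than one place. Compound 1 does carry the same formyl group and stands at 21300 nM, so a move toward a higher number seems somewhat more likely than a move toward a lower one, although this is only a weak hint. The expected change is modest, close to the edge of the scatter, and is estimated as a 1.9-fold higher number from compound 2 to compound 3 (0.28 log units; within the scatter). For compound 3 the estimated value in this assay is 8000 nM, with an expected range from 2500 nM to 25000 nM.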

Compound 3, half-maximal inhibitory concentration: > 50000 nM
Compound 3: only a limit was reported; the forecaster's own chance of this, stated with the estimate: 10%; at least 6.2-fold (0.79 log units) between middle value and limit.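

In this assay compound 3 gives > 50000 nM, which is a limit of the assay and not an exact number: the limit of > 50000 nM in this assay, at which 1 of the 3 values shown sits. Among these compounds, this gives the first direct reading of the oxygen on a saturated carbon: with everything else held the same, putting formyl in place of the group of 7 heavy atoms (6 carbon, 1 silicon) gives an at least 11-fold higher number from compound 2 to compound 3 (1.07 log units; beyond the scatter), so what sits on this oxygen matters greatly for activity in this cell assay. The aromatic carbon also matters, since carboxy in place of fluoro, with formyl present on both compounds, gives an at least 2.3-fold higher number from compound 1 to compound 3 (0.37 log units; beyond the scatter), and because compound 3 sits at a limit, neither step has a known upper size.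

The compounds shown leave open whether a free hydroxyl, a benzoyl group or a longer alkyl chain on that oxygen would retain the activity seen with the silicon-bearing group. They also leave open whether that silicon-bearing group would have a similar effect with fluoro rather than carboxy on the aromatic carbon, or with an amine there.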